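This account rests on a few compounds, and the source may have more. Where it says the series, first, only, none or still open, it means among the compounds named here.

Compound 1 `CC(C)(C)c1ccc(N(C(=O)c2ccco2)C(C(=O)NC2CCCCC2)c2cccnc2)cc1` and compound 2 `C[C@H](NC(=O)C(c1cccnc1)N(C(=O)c1ccco1)c1ccc(C2CCCCC2)cc1)c1ccccc1` share a core and were both tested in a toxicity assay on Vero C1008 cells (Chlorocebus sabaeus) for cytotoxicity, read by neutral red uptake, with a stated time of 5 days; on this read-out lower numbers stand for higher toxicity in this test and higher numbers for lower toxicity in this test. In this assay compound 1 gives 18200 nM, and compound 2 gives 9610 nM; the two numbers lie within the usual scatter of each other, so neither stands apart. Compound 3 `C[C@H](NC(=O)C(c1cccnc1)N(C(=O)c1ccco1)c1ccc(-c2ccccn2)cc1)c1ccccc1` differs from compound 2 by one change: pyridin-2-yl in place of cyclohexyl on an aromatic carbon. Within the data shown here, no measured pair shows the effect of this change, so only a small step, or none beyond the scatter, is expected, as the estimate a 1.6-fold higher number from compound 2 to compound 3 (0.19 log units; within the scatter) describes. Compound 3 is therefore expected to give about 15000 nM, within 5000 nM to 45000 nM.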

Compound 3, half-maximal cytotoxic concentration: 236000 nM
Beside the measured number, compound 3's estimate is 16-fold (1.20 log units) below it, and the stated range ends below it.
By their numbers in this assay, from the lowest: compounds 2 and 1 (each within the scatter of the next); then compound 3.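

This position, on an aromatic carbon para to a large group, is sensitive to what it carries: in this assay, pyridin-2-yl in place of cyclohexyl gives a 25-fold higher number from compound 2 to compound 3 (1.39 log units; beyond the scatter), a large step. The step comes with no change in the count of heavy atoms, since both groups have the same number. Nothing measured here accounts for it. From the compounds shown here alone, whether it follows the ring nitrogen or the aromatic ring stays open. A phenyl or a pyridin-3-yl group at this position would help separate the two.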